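Swapping the Group on the Ester Oxygen of a Shared Core

The compounds below may be only part of what the source reports. "The series", "measured", "known", "first", "only" and "open" are said of these compounds alone.

Measured so far:
compound 1, `CS(=O)(=O)OC1=CC(=O)c2ccccc2C1=O`, 7180 nM
compound 2, `O=C1C=CC(=O)c2cc(OCc3ccccc3)ccc21`, 26200 nM

Both compounds were tested in a functional assay on KB cells (Homo sapiens) for cytotoxicity; a higher number here means a weaker inhibitor, a lower number a stronger inhibitor. Compound 1 gives 7180 nM, the lowest of the two numbers, and so it is the stronger inhibitor of the pair. Compound 2 gives 26200 nM, a higher number that lies beyond the usual scatter, which makes compound 2 the weaker of the two. The two structures differ in more than one place, so their gap cannot be pinned to a single change.

Compound 3, `C/C=C/C(=O)OC1=CC(=O)c2ccccc2C1=O`, has not yet been measured. It differs from compound 1 in one place only: (prop-1-en-1-yl)carbonyl in place of methylsulfonyl on an oxygen on an unsaturated carbon. The oxygen carrying the group and the core around it stay the same.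

Within the data shown here, no step between measured compounds exists here to lean on, so the size of this change in this assay can only be guessed. The expectation is a step of modest size, a 1.6-fold lower number from compound 1 to compound 3 (0.20 log units; within the scatter), leaning toward a lower number but not clearly beyond the scatter. Compound 3 is estimated at 4500 nM, with a range from 1200 nM to 18000 nM.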

Compound 3, half-maximal inhibitory concentration: 64200 nM
For compound 3 the middle estimate is 14-fold (1.15 log units) below the measured one, outside the stated range (above it).
By their numbers in this assay, from the lowest: compound 1; then compound 2; then compound 3.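

In this assay, the group on this oxygen clearly matters: putting (prop-1-en-1-yl)carbonyl in place of methylsulfonyl gives an 8.9-fold higher number from compound 1 to compound 3 (0.95 log units; beyond the scatter). Among these compounds, this is the first comparison here between compounds that differ in one place only, so it shows that the shared core alone does not set the number and that this single change on the oxygen can shift it well beyond the scatter. The two groups have in common that neither has a ring, a net charge or a hydrogen-bond donor, while they differ in heavy atoms and in hydrogen-bond acceptors, but no available evidence links the weaker result to any of these features.

Among the compounds shown here, with only two groups compared on this oxygen, it remains open whether the stronger result belongs to sulfonyl groups in general or to methylsulfonyl alone, a question that ethylsulfonyl or benzenesulfonyl on the same oxygen would help to answer. On these data alone, it also remains open whether the double bond in the entering chain plays any part, which a butanoyl group or a shorter acetyl group in the same place could test.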